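The compounds below may be only part of what the source reports. "The series", "measured", "known", "first", "only" and "open" are said of these compounds alone.

Compound 3 `CC/C(=N\OC)c1ccccc1NCC1=NCCN1` is one of three compounds whose activity has been measured in a functional assay for activation of Alpha-1A adrenergic receptor (Homo sapiens), read by calcium flux; on this read-out higher numbers stand for an effect only at larger amounts of compound and lower numbers for an effect already at smaller amounts. In this assay compound 3 gives 3.31 nM. Compound 1 `c1csc(-c2ccccc2NCC2=NCCN2)c1` gives 2.24 nM in this assay, and compound 2 `c1ccc(-c2cnccn2)c(NCC2=NCCN2)c1` gives 4.57 nM. Compound 3 thus holds the second highest of the three numbers, and both of its neighbours lie within the scatter: the step from compound 1 to compound 3 is a 1.5-fold higher number from compound 1 to compound 3 (0.17 log units; within the scatter), and the step from compound 2 to compound 3 is a 1.4-fold lower number from compound 2 to compound 3 (0.14 log units; within the scatter). For the measured compounds named here, only the step from compound 1 to compound 2, a 2.0-fold higher number from compound 1 to compound 2 (0.31 log units; beyond the scatter), reaches beyond the scatter, and it is modest.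

Compound 4 `CC/C(=N/OC)c1ccccc1NCC1=NCCN1` differs from compound 3 as follows: the two compounds have the same atoms and bonds and differ only in configuration as drawn: 1 of 1 stereo elements differ; a double bond is drawn E in compound 3 and Z in compound 4. Going by the values given here, none of the measured steps concerns a change of configuration; each of them replaces one substituent by another on the shared core, and all three remained small. Among the compounds with values here, the data therefore give no direct guide for the switch from E to Z, and the expectation rests on the narrow spread of all numbers so far. On that basis compound 4 is expected to stay close to compound 3, with a step of a 1.2-fold higher number from compound 3 to compound 4 (0.08 log units; within the scatter) in this assay. The estimate for compound 4 is 4 nM, within a range from 1.5 nM to 12 nM.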

Compound 4, half-maximal effective concentration: 87.1 nM
Estimate against measurement, compound 4: 22-fold (1.34 log units) below; measured number outside the range, above it.
By their numbers in this assay, from the lowest: compounds 1, 3 and 2 (each within the scatter of the next, the first and the last beyond it); then compound 4.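

At this position the configuration of the double bond, rather than the identity of the group, produced the largest effect seen so far in this assay: a 26-fold higher number from compound 3 to compound 4 (1.42 log units; beyond the scatter), with nothing entering or leaving, whereas the earlier replacements of one group by another all stayed small. For the compounds shown here, the Z form also stands well apart from the compounds bearing aromatic rings, with a 19-fold higher number from compound 2 to compound 4 (1.28 log units; beyond the scatter) and a 39-fold higher number from compound 1 to compound 4 (1.59 log units; beyond the scatter), so the tolerance suggested by the earlier compounds holds for the E form of this group and not for its Z form. The large step can be tied to configuration alone because of one structural fact: the fact that compounds 3 and 4 differ only in the configuration as drawn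

The compounds shown leave open whether the same gap between E and Z forms would appear with an ethoxy or benzyloxy group in place of the methoxy group, or with a longer chain in place of the ethyl group. They also leave open how an amine or a carboxylic acid on this aromatic carbon would compare with the groups seen here.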